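A few compounds are considered here, and "the series" means these few. Any claim that something is new, unique, unknown or untested is made for them only; others in the source may bear on it.

In an ADME assay on MDBK cells (Bos taurus) for cytotoxicity, read by MTT assay, with a stated time of 96 h (a lower number here means that less compound is tolerated, a higher number that more compound is tolerated), compound 1 `FC(F)(F)c1cccc(NC(=S)Nc2ccc(I)cc2)c1` gives 9500 nM and compound 2 `Fc1ccc(NC(=S)Nc2cccc(C(F)(F)F)c2)cc1` gives 41000 nM, so compound 2 holds the higher of the two numbers. Within the data shown here, the only measured step, a 4.3-fold higher number from compound 1 to compound 2 (0.64 log units; beyond the scatter), came with fluoro in place of iodo on an aromatic carbon.

Compound 3 `CC(=O)NC(=S)Nc1cccc(C(F)(F)F)c1` has not yet been measured. It differs from compound 2 by acetyl in place of 4-fluorophenyl on an amide-type nitrogen. Among the measured compounds shown here, no measured step covers this kind of change. The step of a 4.3-fold higher number from compound 1 to compound 2 (0.64 log units; beyond the scatter) bears on it only indirectly, as it altered a group on the ring that compound 3 no longer carries. Still, that step offers the sole direction available, so a move toward a higher number in this assay is expected, though a smaller one than that measured step, given how weak the guidance is. The expected size is a 1.8-fold higher number from compound 2 to compound 3 (0.26 log units; within the scatter). For compound 3 the estimated value is 75000 nM, with an expected range from 30000 nM to 190000 nM.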

Compound 3, half-maximal cytotoxic concentration: > 100000 nM
Compound 3: no number, only a limit; the forecaster's own chance of this, stated with the estimate: 35%; middle value at least 1.3-fold (0.12 log units) from the limit.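

Compound 3 gives only a limit in this assay, not a number: the limit of > 100000 nM in this assay, at which 1 of the 3 values shown sits.

Among these compounds, until now the only change was the halogen on a phenyl ring that stayed in place, whereas here the whole aryl group on the amide-type nitrogen gives way to acetyl. That exchange produces an at least 2.4-fold higher number from compound 2 to compound 3 (0.38 log units; beyond the scatter), and acetyl in place of 4-iodophenyl produces an at least 10-fold higher number from compound 1 to compound 3 (1.02 log units; beyond the scatter), the second being a large step and both being beyond the scatter. So this position does not need an aromatic ring for the compound to be tolerated by the cells, and replacing the ring moves the number further than the exchange of halogens did, at least when measured from compound 1, with both steps giving only a lower bound on the true size.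

The acetyl group differs from the aryl groups both in lacking a ring and in bringing a carbonyl, so the compounds shown cannot separate these two differences. A benzoyl group, which holds a ring and a carbonyl together, or a plain ethyl chain, which holds neither, would speak to that question.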